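Swapping a Pyrazole for a Pyridine on a Poorly Soluble Core

A few compounds are considered here, and "the series" means these few. Any claim that something is new, unique, unknown or untested is made for them only; others in the source may bear on it.

Of the compounds shown here, three have been measured in a physicochemical assay for solubility, read by LC-MS, in phosphate buffer, with a stated time of 24 h, at pH 7.4; on this read-out lower numbers stand for lower solubility and higher numbers for higher solubility. Compound 1 `Cc1cc(-c2cnc(NCc3c(F)ccc4c3CCO4)c3cn[nH]c(=O)c23)n(C)n1` gives 1000 nM, the lowest of the three numbers. Compound 2 `COCCC(=O)Nc1cnc(NCc2c(F)ccc3c2CCO3)n2cnnc12` gives 980000 nM, and compound 3 `C[C@H]1CC(=O)N(c2cnc(NCc3c(F)ccc4c3CCO4)n3cnnc23)C1` gives 200000 nM. Within the data shown here, the only measured step between two compounds that differ in one place, a 4.9-fold lower number from compound 2 to compound 3 (0.69 log units; beyond the scatter), swaps a group on a different core from that of compound 1 and so does not speak to the change considered here.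

Compound 4 `Cc1ncccc1-c1cnc(NCc2c(F)ccc3c2CCO3)c2cn[nH]c(=O)c12` differs from compound 1 in one place: 2-methylpyridin-3-yl in place of 1,3-dimethyl-1H-pyrazol-5-yl on an aromatic carbon. Among the measured compounds shown here, no measured compound carries either of these two rings on the core of compound 1, so the data give no direction for this swap and no way to judge its size. I therefore expect a step in this assay from compound 1 to compound 4 of a 1.5-fold higher number from compound 1 to compound 4 (0.18 log units; within the scatter), a change that may well stay within the usual scatter, while keeping the range wide. Compound 4 is expected to give 1500 nM, with a range from 300 nM to 8000 nM.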

Compound 4, solubility: < 2000 nM
Compound 4: only a limit was reported; the forecaster's own chance of this, stated with the estimate: 10%; the middle value lies beyond the limit too.
By their numbers in this assay, from the lowest: compound 1; then compound 3; then compound 2.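

The step from compound 1 to compound 4 cannot be read, since the result for compound 4 is a limit and not a number: the limit of < 2000 nM in this assay, at which 1 of the 4 values shown sits. On these data alone, whether 2-methylpyridin-3-yl gives a higher or lower number than 1,3-dimethyl-1H-pyrazol-5-yl on the core of compound 1 stays open.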